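Configuration Change at the Saturated Ring Carbon

A few compounds are considered here, and "the series" means these few. Any claim that something is new, unique, unknown or untested is made for them only; others in the source may bear on it.

Working notes on the series. Compound 1 `O=C(c1ncc(-c2ccccn2)o1)C1CCc2cc(Oc3ccccc3)ccc2O1` carries an unspecified configuration at its ring carbon, and in an assay on brain for inhibition of Monoacylglycerol lipase ABHD6 (Mus musculus), with a stated time of 10 min (a lower number here means a stronger inhibitor, a higher number a weaker inhibitor), compound 1 gives > 100000 nM; > 100000 nM (2 entries), a limit of the assay rather than a number. One of its two entries rests at the limit of > 100000 nM in this assay, at which 1 of the 2 values shown sits. Compound 2 `O=C(c1ncc(-c2ccccn2)o1)[C@H]1COc2cc(Oc3ccccc3)ccc2C1` is drawn with a defined configuration, and in this assay compound 2 gives > 100000 nM, again a limit and not a number. Compound 2 therefore stands at the weak end of what the assay can report, with no single figure attached to it. Compound 3 `O=C(c1ncc(-c2ccccn2)o1)[C@@H]1COc2cc(Oc3ccccc3)ccc2C1` is the remaining candidate: the two compounds have the same atoms and bonds and differ only in configuration as drawn: 1 of 1 stereo elements differ; a stereocentre at a saturated ring carbon is drawn R in compound 2 and S in compound 3. Going by the values given here, no measured pair in this set shows what such a change does here, so no step beyond the usual scatter is assumed in this assay in either direction. Compound 3 is expected to reach about 100000 nM, within 5000 nM to 500000 nM. The step from compound 2 to compound 3 that this estimate implies is a number no higher from compound 2 to compound 3 (the limit leaves the size open).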

Compound 3, half-maximal inhibitory concentration: > 100000 nM
Compound 3: no number, only a limit; the forecaster's own chance of this, stated with the estimate: 70%; the middle value sits exactly at the limit.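

Going by these compounds alone, compound 2 and compound 3 each give only a limit, not a number, in this assay, and no step between them can be read. The compounds shown leave open whether the configuration at the saturated ring carbon changes inhibition in this assay at all.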